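Swapping a Side Chain in a Purine-Based Analgesic Series

The compounds below may be only part of what the source reports. "The series", "measured", "known", "first", "only" and "open" are said of these compounds alone.

Compound 1 `O=C(CN(c1nc(Cl)nc2[nH]cnc12)C1CC1)NCC(=O)OCc1ccccc1` and compound 2 `N=C(N)NCCC[C@H](NC(=O)CN(c1nc(Cl)nc2[nH]cnc12)C1CC1)C(=O)O` share a core and differ at the amide end. In a functional assay on the whole organism (Tail, strain ICR) with Mus musculus as the target, in the tail flick test, with a stated time of 90 min, at a dose of 12.5 umol/kg by the oral route (a higher number here means a stronger effect of the compound at the dose given, a lower number a weaker effect), compound 1 gives 19%, and compound 2 gives 18.4%, a number within the usual scatter of compound 1. Compound 3 `CC(C)C[C@H](NC(=O)CN(c1nc(Cl)nc2[nH]cnc12)C1CC1)C(=O)O` has not yet been measured. It differs from compound 2 as follows (a group of 3 heavy atoms (3 carbon; no ring) in place of a group of 6 heavy atoms (3 carbon, 3 nitrogen; no ring), on a saturated chain carbon, two bonds along the chain from an amide-type nitrogen and a carbonyl carbon). Within the data shown here, with no step between measured compounds to lean on, the expected step in this assay is a number 1.6 percentage points higher from compound 2 to compound 3 (within the scatter), which is no change beyond the scatter. Compound 3 is therefore expected to give about 20%, with a range from 8% to 35%.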

Compound 3, a percentage reported as activity, at one dose (the size of the read-out at that dose, not a potency): 20.9%
Beside the measured number, compound 3's estimate is 0.9 percentage points below it; the measured number falls inside the stated range.
By their numbers in this assay, from the lowest: compounds 2, 1 and 3 (each within the scatter of the next).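

In this assay, putting isopropyl in place of the group of 6 heavy atoms, on a saturated chain carbon, gives a number 2.5 percentage points higher from compound 2 to compound 3 (within the scatter). At this single dose, the all-carbon isopropyl therefore serves as well as a group carrying 3 nitrogen and 3 hydrogen-bond donors, so those nitrogens are not needed to keep this modest effect. No measurement at hand explains this absence of a clear difference. As far as these compounds go, whether an amine, a phenyl ring or a longer chain at this position would move the number beyond the scatter remains open.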